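One Amino Substitution Compared Across Two Cores

The source may hold more compounds than are shown below. What is called first, only, known or untested is meant among the compounds shown, and "the series" means these compounds.

Compound 1 `COc1ncnc2c1c(-c1cccs1)cn2[C@@H]1O[C@H](CO)[C@@H](O)[C@H]1O` and compound 2 `COc1nc(N)nc2c1c(-c1cccs1)cn2[C@@H]1O[C@H](CO)[C@@H](O)[C@H]1O` share one core, while compound 3 `O=c1[nH]cnc2c1c(-c1cc3ccccc3o1)cn2[C@@H]1O[C@H](CO)[C@@H](O)[C@H]1O` and compound 4 `Nc1nc2c(c(-c3cc4ccccc4o3)cn2[C@@H]2O[C@H](CO)[C@@H](O)[C@H]2O)c(=O)[nH]1` share another; the difference between the two cores is not broken down here. In an ADME assay on BJ cells (Homo sapiens), read by MTT assay, with a stated time of 72 h (a lower number here means a stronger inhibitor, a higher number a weaker inhibitor), compound 1 gives 62800 nM, and compound 2 gives 99900 nM. The change amino in place of hydrogen on an aromatic carbon produced a 1.6-fold higher number from compound 1 to compound 2 (0.20 log units; within the scatter). In this assay compound 3 gives 62700 nM. The change amino in place of hydrogen on an aromatic carbon is the same kind of change, but the surroundings are not identical: on the core of compound 1 the carbon is meta to a methoxy group (2 heavy atoms), whereas on the core of compound 3 it is meta to a group of 1 heavy atom. Because a 1.6-fold higher number from compound 1 to compound 2 (0.20 log units; within the scatter) was the outcome of that change, a step of similar size is expected for compound 4, namely a 1.4-fold higher number from compound 3 to compound 4 (0.16 log units; within the scatter). The estimate for compound 4 in this assay is 90000 nM, expected to fall between 40000 nM and 200000 nM. This expectation rests on a single earlier pair, and the number itself remains to be measured.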

Compound 4, half-maximal inhibitory concentration: > 100000 nM
Compound 4 was reported as a limit (the forecaster's own chance of this, stated with the estimate: 20%); middle value at least 1.1-fold (0.04 log units) from the limit.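

In this assay compound 4 gives > 100000 nM, which is a limit of the assay and not a number. Putting amino in place of hydrogen on the aromatic carbon of the core of compound 3 gave an at least 1.5-fold higher number from compound 3 to compound 4 (0.20 log units; that floor lies within the scatter), so the printed floor of this step lies within the usual scatter and cannot establish a real change on its own. Setting this result beside the same change on the core of compound 1 reveals no disagreement between the two cores, but it does not show that the change carries over with the same size: the same change on two cores in this assay, a 1.6-fold higher number (0.20 log units; within the scatter) from compound 1 to compound 2 and an at least 1.5-fold higher number (0.20 log units; that floor lies within the scatter) from compound 3 to compound 4; the limit leaves it open whether they differ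

The compounds shown leave open how far the number for compound 4 lies past the limit, and so how large the step on this core really is. They also leave open what a methylamino or dimethylamino group would do in place of amino on this carbon, and whether the same step would appear on any further core.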